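Quinolin-4-yl to quinolin-3-yl: notes on compound 3

The source may report more compounds than this note shows. Statements on the series, on what has been measured and on what is new or still open speak of the compounds shown alone.

Compound 1 `CC[C@H]1OC(=O)[C@H](C)[C@@H](O[C@H]2C[C@@](C)(OC)[C@@H](O)[C@H](C)O2)[C@H](C)[C@@H](O[C@@H]2O[C@H](C)C[C@H](N(C)C)[C@H]2OCCCNc2ccnc3cc(Cl)ccc23)[C@](C)(O)C[C@@H](C)CN(C)[C@H](C)[C@@H](O)[C@]1(C)O`: > 10000 ug/mL
Compound 2 `CC[C@H]1OC(=O)[C@H](C)[C@@H](O[C@H]2C[C@@](C)(OC)[C@@H](O)[C@H](C)O2)[C@H](C)[C@@H](O[C@@H]2O[C@H](C)C[C@H](N(C)C)[C@H]2OCCCNCc2ccnc3ccccc23)[C@](C)(O)C[C@@H](C)CN(C)[C@H](C)[C@@H](O)[C@]1(C)O`: > 10000 ug/mL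

In a physicochemical assay for solubility, at pH 4 (on this read-out lower numbers stand for lower solubility and higher numbers for higher solubility), compound 2 gives > 10000 ug/mL. That value is a limit of the assay and not a number, so compound 2 has no exact place in the series. Compound 1 gives > 10000 ug/mL, which is also a limit. Both measured compounds therefore sit at one ceiling: the limit of > 10000 ug/mL in this assay, at which 2 of the 2 values shown sit.

For the measured compounds named here, the only measured step is a step that the two limits leave unreadable from compound 1 to compound 2. It gives no size to carry forward.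

Compound 3 `CC[C@H]1OC(=O)[C@H](C)[C@@H](O[C@H]2C[C@@](C)(OC)[C@@H](O)[C@H](C)O2)[C@H](C)[C@@H](O[C@@H]2O[C@H](C)C[C@H](N(C)C)[C@H]2OCCCNCc2cnc3ccccc3c2)[C@](C)(O)C[C@@H](C)CN(C)[C@H](C)[C@@H](O)[C@]1(C)O` follows from compound 2 by one change: quinolin-3-yl in place of quinolin-4-yl on a saturated chain carbon bound to an amine nitrogen. In words, quinolin-3-yl stands in place of quinolin-4-yl on a saturated chain carbon bound to an amine nitrogen.

Going by the values given here, no measured step bears directly on this swap, so no direction is favoured in this assay, and no step beyond the scatter is expected. The expectation rests only on compound 2 sitting at its limit of > 10000 ug/mL. The expected change is a number no higher from compound 2 to compound 3 (the limit leaves the size open), and this is an estimate.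

Compound 3 is expected at 10000 ug/mL, with an estimated range of 4000 ug/mL to 25000 ug/mL, and a report as a limit again is likely.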

Compound 3, solubility: > 10000 ug/mL
Compound 3: only a limit was reported (the forecaster's own chance of this, stated with the estimate: 80%); the middle value sits exactly at the limit.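

In this assay compound 3 gives > 10000 ug/mL, which is a limit of the assay and not a number. No new step can be read among compound 1, compound 2 and compound 3, because all three sit at one ceiling: the limit of > 10000 ug/mL in this assay, at which 3 of the 3 values shown sit.

The compounds shown leave open the exact solubility of each, and so whether quinolin-3-yl in place of quinolin-4-yl changes the read-out at all.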